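The source may report more compounds than this note shows. Statements on the series, on what has been measured and on what is new or still open speak of the compounds shown alone.

Compound 2 `Fc1ccc(COC(CCn2cncn2)c2cccs2)c(F)c1` gives "not determined" (no result reported) in an ADME assay on J774.A1 cells (Mus musculus) for cytotoxicity, read by MTT assay, with a stated time of 72 h; a lower number here means that less compound is tolerated, a higher number that more compound is tolerated; nothing was reported for it, so it gives no number against which the next compound can be set. The one measured point in this series is compound 1 `Fc1ccc(COC(CCn2ccnc2)c2ccco2)c(F)c1`, which in this assay gives 28800 nM. Compound 3 `Fc1ccc(COC(CCn2ccnc2)c2cccs2)c(F)c1` is the compound that follows from compound 2 by the change (1H-imidazol-1-yl in place of 1H-1,2,4-triazol-1-yl on a saturated chain carbon, three bonds along the chain from an aromatic carbon and an oxygen on a saturated carbon). Since compound 2 carries no value, the size of the step from compound 2 to compound 3 in this assay cannot be read from the data; without any anchor on that side, the expectation is a step of no particular direction, and one not beyond the usual scatter. What can be drawn on is compound 1, which carries the same 1H-imidazol-1-yl group and gives 28800 nM. On that basis compound 3 is expected to give about 25000 nM in this assay, with a likely range from 9000 nM to 70000 nM.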

Compound 3, half-maximal cytotoxic concentration: 34400 nM
The estimate for compound 3 lay 1.4-fold (0.14 log units) below the measured number; the range from low to high includes it.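

With the 1H-imidazol-1-yl group held fixed, thiophen-2-yl in place of furan-2-yl on the saturated chain carbon bound to the oxygen gives a 1.2-fold higher number from compound 1 to compound 3 (0.08 log units; within the scatter) in this assay and so does not separate these two rings. The step from 1H-1,2,4-triazol-1-yl to 1H-imidazol-1-yl cannot be read, so compound 3 adds a second value for the 1H-imidazol-1-yl group but no measure of that change. Nothing available bears on why these values lie where they do.

As far as these compounds go, whether a phenyl ring on that same carbon would give a value within the scatter of those for the furan-2-yl and thiophen-2-yl compounds remains open. So does the effect of an amine or a carboxylic acid at the end of the chain in place of the 1H-imidazol-1-yl group.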